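Replacing 3-methylphenyl with 2-(3-chlorophenyl)ethenyl

This account rests on a few compounds, and the source may have more. Where it says the series, first, only, none or still open, it means among the compounds named here.

Compound 1 `COC(=O)/C=C/c1cccc(N(Cc2ccc(-c3cccc(C)c3)cc2)C(=O)C2CCCCC2)c1`: 109 nM
Compound 2 `COC(=O)/C=C/c1cccc(N(Cc2ccc(-c3cccc(C)c3)cc2)C(=O)C(C)C)c1`: 163 nM
Compound 3 `COC(=O)/C=C/c1cccc(NC(=O)C2CCCCC2)c1`: limit, > 1000 nM

In an assay on isolated protein with Bile acid receptor (Homo sapiens) as the target (a higher number here means that more compound is needed for the effect, a lower number that less compound is needed), compound 1 stands lowest of the two numbers shown; its nearest neighbour is compound 2, with a 1.5-fold higher number from compound 1 to compound 2 (0.17 log units; within the scatter). Compound 3 reports only a limit, (the limit of > 1000 nM in this assay, at which 1 of the 3 values shown sits). Compound 4 `COC(=O)/C=C/c1cccc(N(Cc2ccc(/C=C/c3cccc(Cl)c3)cc2)C(=O)C2CCCCC2)c1` differs from compound 1 in one place: 2-(3-chlorophenyl)ethenyl in place of 3-methylphenyl on an aromatic carbon. Within the data shown here, no measured step touches this position; the single measured step concerns the group on the carbonyl carbon and stayed within the scatter, so no step beyond the scatter is expected in this assay either. Compound 4 is therefore estimated at 100 nM, between 35 nM and 300 nM, meaning an expected step of a 1.1-fold lower number from compound 1 to compound 4 (0.04 log units; within the scatter).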

Compound 4, half-maximal effective concentration: 165 nM
Compound 4: the middle estimate sits 1.7-fold (0.22 log units) below what was measured, within the range that was stated.
By their numbers in this assay, from the lowest: compounds 1, 2 and 4 (each within the scatter of the next). At a limit, above all of these: compound 3.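

In this assay the exchange of 3-methylphenyl for 2-(3-chlorophenyl)ethenyl gives a 1.5-fold higher number from compound 1 to compound 4 (0.18 log units; within the scatter) and so moves the number by no more than the usual scatter. This aromatic carbon, para to a large group, therefore accepts a larger group carrying a chlorine and a double bond outside the aromatic ring, with no step beyond the scatter. Nothing shown gives a reason for this outcome.

The compounds shown leave open how an amine or a carboxylic acid would fare at this position. They also do not separate the part played by the chlorine from that of the ethenyl link, which a plain 2-phenylethenyl or a directly attached 3-chlorophenyl would address.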